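The compounds below may be only part of what the source reports. "The series", "measured", "known", "first", "only" and "open" are said of these compounds alone.

Measured in a functional assay on the whole organism for inhibition, with Rattus norvegicus as the target; on this read-out higher numbers stand for an effect only at larger amounts of compound and lower numbers for an effect already at smaller amounts:
- Compound 1 `CC(C)c1ccc(OC(C)(Cc2cccc(C(F)(F)F)c2)C(=O)O)cc1`: 5 mg/kg.
- Compound 2 `Cc1cccc(CC(C)(Oc2ccc(C(C)C)cc2)C(=O)O)c1`: < 1 mg/kg, a limit.
- Compound 3 `CC(C)c1ccc(OC(C)(Cc2ccc(Cl)cc2)C(=O)NS(C)(=O)=O)cc1`: 5 mg/kg.

Compound 3 stands level with compound 1, with no change at the digits shown. Compound 4 `Cc1ccccc1S(=O)(=O)NC(=O)C(C)(Cc1ccc(Cl)cc1)Oc1ccc(C(C)C)cc1` has 2-methylphenyl in place of methyl on a sulfonyl sulfur. Within the data shown here, the one measured step, an at least 5.0-fold lower number from compound 1 to compound 2 (0.69 log units; beyond the scatter), is methyl in place of trifluoromethyl on an aromatic carbon. That step ends on a limit for compound 2, (the limit of < 1 mg/kg in this assay, at which 1 of the 3 values shown sits). It does not involve the sulfonyl sulfur, so its size does not carry over. The expected result in this assay is no change at the digits printed from compound 3 to compound 4 (within the scatter), with no shift beyond the scatter in either direction. This expectation starts from compound 3 at 5 mg/kg. Compound 4 is estimated at 5 mg/kg, with an expected range of 1.5 mg/kg to 15 mg/kg.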

Compound 4, dose for half-maximal effect: > 10 mg/kg
Compound 4 gave a limit, no number; the forecaster's own chance of this, stated with the estimate: 20%; middle value at least 2.0-fold (0.30 log units) from the limit.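

Among these compounds, on the sulfonyl sulfur, 2-methylphenyl in place of methyl gives an at least 2.0-fold higher number from compound 3 to compound 4 (0.30 log units; that floor lies within the scatter), the first reading at this position, as the earlier step concerned only an aromatic carbon. In this assay compound 4 is a limit and not a number: the limit of > 10 mg/kg in this assay, at which 1 of the 4 values shown sits. The change therefore has no measured size, and its floor alone does not establish a shift beyond the scatter.

Open, going by these compounds, is whether plain phenyl or a longer chain such as butyl on the sulfonyl sulfur would stay level with compound 3 at 5 mg/kg. Also open, on these data alone, is how a carboxylic acid in place of the methanesulfonamido group would read on the core of compound 3.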